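This account rests on a few compounds, and the source may have more. Where it says the series, first, only, none or still open, it means among the compounds named here.

Measured so far, in an assay on isolated protein for inhibition of DNA topoisomerase 1 (Homo sapiens), with a stated time of 30 min, tested at 100 uM; on this read-out lower numbers stand for a weaker effect and higher numbers for a stronger effect at the one concentration tested:
compound 1 `Oc1ccc(-c2cc(-c3ccccc3)nc(-c3ccccc3Cl)c2)cc1` gives 13.6%
compound 2 `Oc1ccc(-c2cc(-c3ccco3)nc(-c3ccccc3Cl)c2)cc1` gives 3.9%
compound 3 `Oc1ccc(-c2cc(-c3ccsc3)nc(-c3ccccc3Cl)c2)cc1` gives 4.1%

Compound 1 holds the largest of the three numbers, but the steps of a number 9.7 percentage points lower from compound 1 to compound 2 (within the scatter) and a number 9.5 percentage points lower from compound 1 to compound 3 (within the scatter) both sit within the scatter, so the three compounds cannot be told apart on this read-out. All three stay at modest inhibition.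

Compound 4 `Oc1ccc(-c2cc(-c3ccccc3)nc(-c3ccc(Cl)cc3)c2)cc1` is not yet measured. It differs from compound 1 by 4-chlorophenyl in place of 2-chlorophenyl on an aromatic carbon. Among the compounds with values here, none of the measured steps changes the chlorophenyl group; they all swap the group on the other side of the shared core, and every one of them stayed within the scatter. Within the data shown here, no measured step therefore bears directly on this change, and no step beyond the scatter is expected in this assay. The estimated step of a number 1.6 percentage points lower from compound 1 to compound 4 (within the scatter) is expected to remain within the scatter. Compound 4 is expected to give about 12%, estimated between 0% and 30%.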

Compound 4, a percentage reported as inhibition, at one concentration (the size of the read-out at that concentration, not a potency): 68%
For compound 4 the middle estimate is 56 percentage points below the measured one, outside the stated range (above it).
By their numbers in this assay, from the lowest: compounds 2, 3 and 1 (each within the scatter of the next); then compound 4.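

Read in this assay with the same atoms on both sides, 4-chlorophenyl in place of 2-chlorophenyl gives a number 54.4 percentage points higher from compound 1 to compound 4 (beyond the scatter) and is the only step shown that lies beyond the scatter. This position, next to the ring nitrogen, therefore responds strongly to where the chlorine sits on the phenyl ring, whereas swaps of the phenyl group on the other side of the shared core could not be told apart. No measurement shown explains this jump. Still open, from the compounds shown here alone, is whether an amine or a methoxy group could replace the chlorine of 4-chlorophenyl and keep this level. Also open, going by these compounds, is whether the gain holds with furan-2-yl or thiophen-3-yl on the other side.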